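Bromophenyl to dihydrobenzofuranyl at the amine-bearing carbon

A few compounds are considered here, and "the series" means these few. Any claim that something is new, unique, unknown or untested is made for them only; others in the source may bear on it.

Measured compounds in an assay on HEK293 cells for antagonist activity at transient receptor potential M8 protein (Canis lupus familiaris), read by fluorescence and calcium flux, with a stated time of 5 min; on this read-out lower numbers stand for stronger inhibition and higher numbers for weaker inhibition:
- compound 1, `O=C(C(Nc1ccccc1)c1ccc(C(F)(F)F)cc1)N1CCCC1c1ccccc1F`, compound 1 gives 30 nM
- compound 2, `O=C(C(Nc1ccc(F)cc1)c1ccc(C(F)(F)F)cc1)N1CCCC1c1ccccc1Cl`, compound 2 gives 73 nM
- compound 3, `O=C(C(Nc1ccccc1F)c1ccc(Br)cc1)N1CCC[C@H]1c1ccccc1F`, compound 3 gives 9 nM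

Compound 3 has the lowest number of the three, and its steps to compound 1 and to compound 2 both lie beyond the scatter, so within this small set compound 3 is the most potent. Compound 1 and compound 2 differ from compound 3 in more than one place, so nothing is said about any single change among them.

Compound 4, `O=C(C(Nc1ccccc1F)c1ccc2c(c1)CCO2)N1CCC[C@H]1c1ccccc1F`, is not yet measured. The change from compound 3 to compound 4 is a group of 9 heavy atoms (8 carbon, 1 oxygen; one five-membered non-aromatic ring with 1 hetero atom, one six-membered aromatic ring of carbon only) in place of a group of 7 heavy atoms (6 carbon, 1 bromine; one six-membered aromatic ring of carbon only), on a saturated chain carbon bound to a carbonyl carbon and a nitrogen on an aromatic ring. For the measured compounds named here, no step of this kind between measured compounds is available, so the expectation rests on the general level of the series. A small change, within or close to the scatter, is expected in this assay, with a slight drift toward a higher number. Compound 4 is therefore estimated at 18 nM, with a range from 6 nM to 55 nM, which means an expected step of a 2.0-fold higher number from compound 3 to compound 4 (0.30 log units; within the scatter).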

Compound 4, half-maximal inhibitory concentration: 14 nM
For compound 4 the middle estimate is 1.3-fold (0.11 log units) above the measured one; low and high end bracket the measured number.
By their numbers in this assay, from the lowest: compounds 3 and 4 (each within the scatter of the next); then compound 1; then compound 2.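

For the compounds shown here, this is the only step that changes one place alone. At the saturated chain carbon bound to a carbonyl carbon and a nitrogen on an aromatic ring, this assay shows a 1.6-fold higher number from compound 3 to compound 4 (0.19 log units; within the scatter), so the 4-bromophenyl can be exchanged for a group with a five-membered non-aromatic ring and one hydrogen-bond acceptor, without bromine, and the read-out stays within the scatter. No measurement at hand offers a reason why these two groups read alike.

Open, as far as these compounds go, is how a plain phenyl or a pyridine ring would read at this place, which would help separate the part played by the bromine from that of the ring oxygen. Also open, from the compounds shown here alone, is whether the exchange reads the same against the trifluoromethyl-bearing compound 1 and compound 2.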